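The compounds below may be only part of what the source reports. "The series", "measured", "known", "first", "only" and "open" are said of these compounds alone.

Measured compounds:
compound 1, `COc1ccc2c(c1)c(C1CC(c3ccncc3)=NO1)cn2Cc1ccc(Cl)cc1`; in a functional assay on PC-3 cells (Homo sapiens) for inhibition, read by MTT assay, with a stated time of 48 h (on this read-out lower numbers stand for stronger inhibition and higher numbers for weaker inhibition), compound 1 gives 55200 nM.
compound 2, `c1ccc2c(C3CC(c4ccncc4)=NO3)c[nH]c2c1`; in this assay compound 2 gives > 100000 nM, which is a limit of the assay and not a number.

Compound 2 therefore stands at the limit of > 100000 nM in this assay, at which 1 of the 2 values shown sits, and only compound 1 carries a measured number in this assay. Compound 3, `COc1ccc2[nH]cc(C3CC(c4ccncc4)=NO3)c2c1`, is not yet measured and differs from compound 2 by methoxy in place of hydrogen on an aromatic carbon. Going by the values given here, no measured pair isolates this change; compound 1 carries the same methoxy together with a chlorobenzyl on the ring nitrogen, and its value marks where a measured member of the series sits. Since compound 2 reaches only a limit, the step to compound 3 cannot be anchored from below. The step from compound 2 to compound 3 is expected to be modest, toward stronger inhibition, as an at least 1.2-fold lower number from compound 2 to compound 3 (0.09 log units; that floor lies within the scatter). Compound 3 is expected to give about 80000 nM in this assay, within 30000 nM to 200000 nM, with a real chance that only a limit is reported again.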

Compound 3, half-maximal inhibitory concentration: > 100000 nM
Compound 3 ended at the assay's limit; the forecaster's own chance of this, stated with the estimate: 55%; middle value at least 1.2-fold (0.09 log units) from the limit.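

In this assay compound 3 gives > 100000 nM, which is a limit of the assay and not a number, so methoxy in place of hydrogen on this aromatic carbon does not by itself bring the shared core to a measured value. Any effect of this change stays hidden, and the step between compound 2 and compound 3 cannot be read: the limit of > 100000 nM in this assay, at which 2 of the 3 values shown sit.

Going by these compounds alone, the single readable change is hydrogen in place of 4-chlorobenzyl on the aromatic nitrogen, which gives an at least 1.8-fold higher number from compound 1 to compound 3 (0.25 log units; that floor lies within the scatter), so this pair sets only a floor on the size of the step, and compound 1 remains the one member of the series with a measured number.

Still open, as far as these compounds go, is how the 4-chlorobenzyl group on the aromatic nitrogen behaves without the methoxy, which would show whether the methoxy contributes anything to the value of compound 1. Also open, from the compounds shown here alone, is whether a plain benzyl, a longer alkyl chain or a chain ending in an amine on that nitrogen, or a fluorine or hydroxyl in place of the methoxy, would move the series further from the limit.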